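A few compounds are considered here, and "the series" means these few. Any claim that something is new, unique, unknown or untested is made for them only; others in the source may bear on it.

Measured in an ADME assay on HepG2 cells (Homo sapiens) for cytotoxicity, read by luminescence, CellTiter-Glo and ATP content, with a stated time of 72 h; on this read-out lower numbers stand for an effect already at smaller amounts and higher numbers for an effect only at larger amounts of compound:
compound 1 `COc1ccc(-c2ccc3c(NCCCNCc4cccc(OC)c4O)ccnc3c2)cc1`: 1600 nM
compound 2 `COc1cccc(CNCCCNc2ccnc3cc(C4CCCCC4)ccc23)c1O`: 1080 nM
compound 3 `COc1cccc(CNCCCNc2ccnc3cc(Cc4ccccc4)ccc23)c1O`: 5720 nM

Compound 3 at 5720 nM has the highest number of the three. Compound 4 `COc1cccc(CNCCCNc2ccnc3cc(Oc4ccc(Cl)cc4)ccc23)c1O` carries 4-chlorophenoxy in place of benzyl on an aromatic carbon. Two measured steps bring benzyl into this place, a 3.6-fold higher number from compound 1 to compound 3 (0.55 log units; beyond the scatter) and a 5.3-fold higher number from compound 2 to compound 3 (0.72 log units; beyond the scatter), both modest. The groups it replaced stay within the scatter of each other, a 1.5-fold lower number from compound 1 to compound 2 (0.17 log units; within the scatter). Among the measured compounds shown here, no measured compound has a 4-chlorophenoxy group, so the transfer is loose. A modest move to a lower number is expected in this assay on leaving benzyl. The expected step is a 2.9-fold lower number from compound 3 to compound 4 (0.46 log units; beyond the scatter). For compound 4 the estimated value is 2000 nM, with an expected range from 700 nM to 6000 nM.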

Compound 4, half-maximal effective concentration: 5700 nM
Compound 4: the middle estimate sits 2.9-fold (0.45 log units) below what was measured, and the stated range covers the measured number.
By their numbers in this assay, from the lowest: compounds 2 and 1 (each within the scatter of the next); then compounds 4 and 3 (each within the scatter of the next).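

In this assay, 4-chlorophenoxy in place of benzyl gives a 1.0-fold lower number from compound 3 to compound 4 (0.00 log units; within the scatter) and so keeps this position at the high end of the series. The new group also stands apart from the directly attached rings, with a 5.3-fold higher number from compound 2 to compound 4 (0.72 log units; beyond the scatter) and a 3.6-fold higher number from compound 1 to compound 4 (0.55 log units; beyond the scatter) at this position, so among these four compounds the two groups joined through a single linking atom give the higher numbers. No evidence is available to explain this grouping.

On these data alone, the separate parts played by the linking oxygen and the chlorine remain open. Plain phenoxy or an anilino group at this position would help separate them.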